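This account rests on a few compounds, and the source may have more. Where it says the series, first, only, none or still open, it means among the compounds named here.

Measured so far in an ADME assay on the whole organism for pharmacokinetics, with Rattus norvegicus as the target, at a dose of 3 mg/kg by the intravenous route; a lower number here means that more of the compound stays in the plasma, a higher number that more of the compound sits outside the plasma:
- compound 1 `COC(=O)N[C@H](C(=O)N1CCC[C@H]1C(=O)Nc1ccc([C@@H]2CC[C@@H](c3ccc(NC(=O)[C@@H]4CCCN4C(=O)[C@@H](NC(=O)OC)[C@@H](C)OC)cc3)N2c2ccc(F)cc2)cc1)[C@@H](C)OC`: 1.3 L/kg
- compound 2 `COC(=O)N[C@H](C(=O)N1CCC[C@H]1C(=O)Nc1ccc([C@@H]2CC[C@@H](c3ccc(NC(=O)[C@@H]4CCCN4C(=O)[C@@H](NC(=O)OC)C(C)C)cc3)N2c2ccc(F)cc2)cc1)C(C)C`: 2.4 L/kg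
- compound 3 `COC(=O)N[C@H](C(=O)N1CCC[C@H]1C(=O)Nc1ccc([C@@H]2CC[C@@H](c3ccc(NC(=O)[C@@H]4CCCN4C(=O)[C@@H](NC(=O)OC)[C@H]4CCOC4)cc3)N2c2ccc(F)cc2)cc1)[C@H]1CCOC1`: 0.5 L/kg

Compound 1 stands second highest of the three numbers. The nearest is compound 2, whose 2.4 L/kg lies within the usual scatter of the value of compound 1, so no order between those two can be read. The furthest is compound 3, whose 0.5 L/kg sits beyond the scatter below compound 1. Among the measured compounds shown here, no step between any two of the measured compounds is given, and none of them differs from another in configuration alone, so no measured step speaks directly to a change of configuration.

Compound 4 `COC(=O)N[C@H](C(=O)N1CCC[C@H]1C(=O)Nc1ccc([C@H]2CC[C@H](c3ccc(NC(=O)[C@@H]4CCCN4C(=O)[C@@H](NC(=O)OC)[C@@H](C)OC)cc3)N2c2ccc(F)cc2)cc1)[C@@H](C)OC` is the next candidate. Against compound 1 the change is this: the two compounds have the same atoms and bonds and differ only in configuration as drawn: 2 of 8 stereo elements differ; a stereocentre at a saturated ring carbon is drawn S in compound 1 and R in compound 4; a stereocentre at a saturated ring carbon is drawn S in compound 1 and R in compound 4. The atoms and bonds are unchanged; only the drawn configuration at two saturated ring carbons of the shared core is inverted. With nothing measured that bears on such an inversion, the expectation for this assay is a step in no particular direction and not beyond the scatter, and the estimated step from compound 1 to compound 4 is therefore no change at the digits printed from compound 1 to compound 4 (within the scatter). For compound 4 the estimate in this assay is 1.3 L/kg, expected to fall between 0.6 L/kg and 2.8 L/kg.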

Compound 4, volume of distribution at steady state: 0.9 L/kg
Beside the measured number, compound 4's estimate is 1.4-fold (0.16 log units) above it; the measured number falls inside the stated range.
By their numbers in this assay, from the lowest: compounds 3, 4, 1 and 2 (each within the scatter of the next, the first and the last beyond it).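

In this assay, among the compounds shown here, the first direct reading of a configuration change is a 1.4-fold lower number from compound 1 to compound 4 (0.16 log units; within the scatter). At the two saturated ring carbons of the shared core, this inversion therefore gives no step beyond the scatter, so no order can be read between the two configurations. The reading is clean in one respect, as no other structural change enters this comparison: the fact that compounds 1 and 4 differ only in the configuration as drawn

This holds for a single pair only, and the compounds shown do not tell whether the same inversion stays within the scatter when the core carries the groups that set compound 2 or compound 3 apart from compound 1. Also open, from the compounds shown here alone, is how this assay responds when an amine or a carboxylic acid enters those groups, or a nitrile takes the place of the fluorine.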